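Benzylamine substitution in the biaryl series: methyl to diethyl

The source may report more compounds than this note shows. Statements on the series, on what has been measured and on what is new or still open speak of the compounds shown alone.

Measured so far:
compound 1, `CCCN(CCC)Cc1ccc(Cl)c(-c2ccccc2OC)c1`: > 10000 nM
compound 2, `CNCc1ccc(Cl)c(-c2ccccc2OC)c1`: 1200 nM

Among the measured compounds shown here, compound 2 is the only compound of the pair with a numeric value in an assay on isolated protein for binding affinity to 5-hydroxytryptamine receptor 1D (Homo sapiens); on this read-out lower numbers stand for stronger inhibition and higher numbers for weaker inhibition; compound 2 gives 1200 nM. Compound 1 reaches only a limit of the assay, > 10000 nM, so its true value is not known (the limit of > 10000 nM in this assay, at which 1 of the 2 values shown sits).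

For the measured compounds named here, the single measured step runs an at least 8.3-fold lower number from compound 1 to compound 2 (0.92 log units; beyond the scatter). Compound 3, `CCN(CC)Cc1ccc(Cl)c(-c2ccccc2OC)c1`, differs from compound 2 by diethylamino in place of methylamino on a saturated chain carbon bound to an aromatic carbon. This change runs in the direction opposite to the measured step, toward a bulkier amine, though diethylamino stops short of dipropylamino. Since that step gave a higher number for the larger amine, the number for compound 3 is expected to rise, but less than for compound 1. The estimated step is a 3.8-fold higher number from compound 2 to compound 3 (0.57 log units; beyond the scatter). Compound 3 is therefore estimated at 4500 nM, within 1500 nM to 15000 nM.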

Compound 3, inhibition constant: > 10000 nM
Compound 3: a limit, no number (the forecaster's own chance of this, stated with the estimate: 30%); middle value at least 2.2-fold (0.34 log units) away from the limit.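

In this assay compound 3 stands at a limit of the assay, > 10000 nM, and not at a number. Diethylamino in place of methylamino gives an at least 8.3-fold higher number from compound 2 to compound 3 (0.92 log units; beyond the scatter), so the loss seen with dipropylamino in compound 1 is already present with the smaller diethylamino, and of the three amines on this saturated chain carbon only methylamino in compound 2 gives a number. The step between compound 1 and compound 3 cannot be read, as both values are limits of the assay: the limit of > 10000 nM in this assay, at which 2 of the 3 values shown sit.

On these data alone, whether the unsubstituted primary amine, dimethylamino or a ring amine such as pyrrolidine would give a lower or higher number than compound 2 remains open. As far as these compounds go, the true values of compound 1 and compound 3 also remain open, so no order can be given between the diethylamino and dipropylamino groups.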